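Cyclopropyl for methyl on the pyrazole: a second look

This account rests on a few compounds, and the source may have more. Where it says the series, first, only, none or still open, it means among the compounds named here.

Compound 1 `Cc1cc(Nc2nc(NCc3ccc(F)cc3F)nc3ccc(Cl)cc23)n[nH]1` — 520 nM
Compound 2 `Fc1ccc(CNc2nc(Nc3cc(C4CC4)[nH]n3)c3cc(Cl)ccc3n2)c(F)c1` — 72 nM
Compound 3 `Cc1cc(Nc2nc(NCc3ccc(F)cc3F)nc3cc(Cl)ccc23)n[nH]1` — 15 nM

Of the compounds shown here, three have been measured in an assay for inhibition of high affinity nerve growth factor receptor (Homo sapiens), read by HTRF, with a stated time of 30 min, in the presence of a further agent that is not named here; on this read-out higher numbers stand for weaker inhibition and lower numbers for stronger inhibition. Compound 1 gives 520 nM, compound 2 gives 72 nM, and compound 3 gives 15 nM, the lowest of the three numbers. Compound 2 differs from compound 1 by one change, (cyclopropyl in place of methyl on an aromatic carbon), and that change brought a 7.2-fold lower number from compound 1 to compound 2 (0.86 log units; beyond the scatter). Compound 3 and compound 1 are built from the same atoms joined differently; the difference between the two cores is not broken down here.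

Compound 4 `Fc1ccc(CNc2nc(Nc3cc(C4CC4)[nH]n3)c3ccc(Cl)cc3n2)c(F)c1` is not yet measured. It stands to compound 3 as compound 2 stands to compound 1: the change is cyclopropyl in place of methyl on an aromatic carbon, the same change made on the core of compound 3. Because the earlier step was a 7.2-fold lower number from compound 1 to compound 2 (0.86 log units; beyond the scatter), a step of similar size and direction is expected here, and the estimate for compound 3 to compound 4 in this assay is a 5.0-fold lower number from compound 3 to compound 4 (0.70 log units; beyond the scatter). Compound 4 is therefore expected to give about 3 nM in this assay, most likely falling in the range from 1.2 nM to 8 nM.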

Compound 4, half-maximal inhibitory concentration: 290 nM
Beside the measured number, compound 4's estimate is 97-fold (1.99 log units) below it; measured number above the stated range.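

Moved to the other core, cyclopropyl in place of methyl went the opposite way: in this assay the change brought a 19-fold higher number from compound 3 to compound 4 (1.29 log units; beyond the scatter), a large step against the earlier fall. The gain seen on the core of compound 1 therefore did not carry over, and the two steps differ by more than repeated measurement would explain: the same change on two cores in this assay, a 7.2-fold lower number (0.86 log units; beyond the scatter) from compound 1 to compound 2 and a 19-fold higher number (1.29 log units; beyond the scatter) from compound 3 to compound 4, 140-fold (2.14 log units) apart, beyond the scatter of two such steps. Among these compounds, this shows that the effect of the change depends on the core that carries it, but with only one pair on each core it does not show which difference between the cores is responsible, or how the change would behave on any further core.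

The compounds shown leave open whether the reversal is peculiar to cyclopropyl or would also appear on these two cores with another group in its place, such as ethyl, isopropyl or tert-butyl. They also leave open whether the same reversal would be seen in any other kind of assay.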